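Removing a Methyl from the Aryl of Compound 1

This account rests on a few compounds, and the source may have more. Where it says the series, first, only, none or still open, it means among the compounds named here.

Measured compounds:
- compound 1, `Cc1ccc(-c2nn(-c3ccccc3)cc2C(=O)NC(=S)Nc2ccc(Cl)cc2)cc1`: 3650 nM
- compound 2, `O=C(NC(=S)Nc1ccc(F)cc1)c1cn(-c2ccccc2)nc1-c1ccc(F)cc1`: 3240 nM

Of the compounds shown here, two sharing the core of compound 1 have been tested in a functional assay on NCI-H460 cells (Homo sapiens) for inhibition, read by CCK-8 assay, with a stated time of 48 h; on this read-out lower numbers stand for stronger inhibition and higher numbers for weaker inhibition. Compound 1 gives 3650 nM, and compound 2 gives 3240 nM. Compound 1 holds the higher of the two numbers, but the gap to compound 2 is within the scatter, so the two values show no real separation. Going by the values given here, compound 1 and compound 2 differ in more than one place, so no single step between them is counted here.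

The unmeasured compound 3, `O=C(NC(=S)Nc1ccc(Cl)cc1)c1cn(-c2ccccc2)nc1-c1ccccc1`, comes from compound 1 by a single change: hydrogen in place of methyl on an aromatic carbon, on an aromatic carbon of a six-membered aromatic ring of carbon only, para to a large group; read one bond further out, 4-methylphenyl becomes phenyl.

Among the compounds with values here, with no measured step of this kind available, and given that the two measured compounds sit close together, the step from compound 1 to compound 3 is expected to be small, in no firm direction, and likely within the scatter, as a 1.0-fold lower number from compound 1 to compound 3 (0.01 log units; within the scatter). Compound 3 is therefore estimated at 3600 nM in this assay, with a range from 1500 nM to 8500 nM.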

Compound 3, half-maximal inhibitory concentration: 4020 nM
Beside the measured number, compound 3's estimate is 1.1-fold (0.05 log units) below it; low and high end bracket the measured number.
By their numbers in this assay, from the lowest: compounds 2, 1 and 3 (each within the scatter of the next).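

The earlier compounds shown here offered no single step at this place, and one can now be read: in this assay, going from 4-methylphenyl to phenyl gives a 1.1-fold higher number from compound 1 to compound 3 (0.04 log units; within the scatter), so this change leaves no measurable mark. On this aromatic carbon, in the setting of compound 1, hydrogen and methyl therefore cannot be told apart by this read-out, and the level of inhibition does not depend on that one carbon. No information at hand bears on why this position responds so little to this change.

Methyl and hydrogen are only two small substituents, so it remains open whether a methoxy group, an amine, a carboxylic acid or a longer alkyl chain on the same aromatic carbon would produce a step beyond the scatter. This is also a single step in a single setting, so whether removing the methyl reads the same way when other parts of the shared core carry different groups remains unanswered.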